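Notes on the step to compound 4

This account rests on a few compounds, and the source may have more. Where it says the series, first, only, none or still open, it means among the compounds named here.

Measured in a functional assay on ASPC1 cells (Homo sapiens) for inhibition, read by MTT assay, with a stated time of 96 h; a lower number here means a stronger inhibitor of growth, a higher number a weaker inhibitor of growth:
compound 1 `O=C(NCCCCCCSSCCCCCCNC(=O)c1cc(-c2ccncc2)n[nH]1)c1cc(-c2ccncc2)n[nH]1` gives 25300 nM
compound 2 `CC(C)C(=O)SCCCCCCNC(=O)c1cc(-c2ccncc2)n[nH]1` gives 31700 nM
compound 3 `CCCCCCCC/C=C\CCCCCCCC(=O)SCCCCCCNC(=O)c1cc(-c2ccncc2)n[nH]1` gives > 50000 nM (a limit of the assay)

Compound 1 at 25300 nM and compound 2 at 31700 nM lie within the scatter of each other. Compound 3 reports only a limit, > 50000 nM.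

Compound 4 `CCC(=O)SCCCCCCNC(=O)c1cc(-c2ccncc2)n[nH]1` has not yet been measured. It differs from compound 2 by hydrogen in place of methyl on a saturated chain carbon bound to a carbonyl carbon and a saturated chain carbon, with hydrogen in place of methyl on a saturated chain carbon bound to a carbonyl carbon and a saturated chain carbon. This turns isopropylcarbonyl into propanoyl.

Among the measured compounds shown here, no measured pair differs in one place, so no step is available as a guide. The expectation rests on the small size of this change and on compound 2 at 31700 nM. In this assay no shift beyond the scatter is expected. The expected step is a 1.1-fold lower number from compound 2 to compound 4 (0.02 log units; within the scatter). For compound 4 the estimated value is 30000 nM, with an expected range of 16000 nM to 50000 nM.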

Compound 4, concentration for 50% growth inhibition: > 50000 nM
Compound 4: only a limit was reported; the forecaster's own chance of this, stated with the estimate: 15%; middle value at least 1.6-fold (0.22 log units) away from the limit.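

Hydrogen in place of methyl on this saturated chain carbon, turning isopropylcarbonyl into propanoyl, gives the first single-place step in the series in this assay: an at least 1.5-fold higher number from compound 2 to compound 4 (0.19 log units; that floor lies within the scatter). For compound 4, > 50000 nM is a limit of the assay and not a number. The step therefore has only a floor, and that floor lies within the scatter, so this small change at this position cannot yet be called a real shift, nor can its full size be read: the limit of > 50000 nM in this assay, at which 2 of the 4 values shown sit.

From the compounds shown here alone, whether a measured number for compound 4 would fall within the scatter of compound 2 remains open. Also open, going by these compounds, is whether a tert-butyl or cyclopropyl group in place of isopropyl, or an amine on the acyl chain, would give a measured value in this assay.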